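Metabolic stability notes: benzyl to hexyl on the amine

A few compounds are considered here, and "the series" means these few. Any claim that something is new, unique, unknown or untested is made for them only; others in the source may bear on it.

Measured compounds:
compound 1 `CC(C)N/C(=N\C1=NC(=O)C(=O)N1C(C)C)Nc1ccc(Cl)c(Cl)c1`
compound 2 `CC(C)N1C(=O)C(=O)N=C1/N=C(\NCc1ccccc1)Nc1ccc(Cl)c(Cl)c1`

In an in vitro ADME assay on microsomes from liver (Mus musculus) for metabolic stability, read by LC-MS (a lower number here means that the compound disappears faster, a higher number that the compound lasts longer), compound 1 gives > 1 h, which is a limit of the assay and not a number. In this assay compound 2 gives > 1 h, also a limit. The step that the two limits leave unreadable from compound 1 to compound 2 is accordingly unreadable. Compound 2 stands at the limit of > 1 h in this assay, at which 2 of the 2 values shown sit. Compound 3 `CCCCCCN/C(=N\C1=NC(=O)C(=O)N1C(C)C)Nc1ccc(Cl)c(Cl)c1` differs from compound 2 by pentyl in place of phenyl on a saturated chain carbon bound to an amine nitrogen. No measured step reads on this change, since the only step shown is hidden by the limits. For compound 3 a step that the limit leaves unreadable from compound 2 to compound 3 is expected, with no direction beyond the scatter. The estimate for compound 3 in this assay is 1.5 h, range 0.5 h to 4 h, and a result reported only as a limit is expected to be the most likely outcome.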

Compound 3, half-life: 0.579 h
Compound 3: middle estimate off by 2.6-fold (0.41 log units), on the high side, and the stated range covers the measured number.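

In this assay, within the data shown here, compound 3 gives the first readable number for a group on this amine nitrogen: 0.579 h. Benzyl to hexyl gives an at least 1.7-fold lower number from compound 2 to compound 3 (0.23 log units; that floor lies within the scatter), and isopropyl to hexyl gives an at least 1.7-fold lower number from compound 1 to compound 3 (0.23 log units; that floor lies within the scatter), so a real drop with hexyl is possible but not established. The step between compound 1 and compound 2 cannot be read, and the full size of the two new steps stays unknown: the limit of > 1 h in this assay, at which 2 of the 3 values shown sit.

Going by these compounds, it remains open whether the hexyl result follows from chain length or from the loss of the phenyl ring. On these data alone, how a longer chain or a cyclohexyl group would read in this assay is also open.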